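N-Alkyl Size on the Azole Ring and Agonist Potency

A few compounds are considered here, and "the series" means these few. Any claim that something is new, unique, unknown or untested is made for them only; others in the source may bear on it.

Measured so far in an in vitro functional assay on cells (Fibroblast) for agonist activity at Alpha-1A adrenergic receptor (Homo sapiens); on this read-out higher numbers stand for an effect only at larger amounts of compound and lower numbers for an effect already at smaller amounts:
compound 1 `CC(C)n1nccc1-c1ccccc1NCC1=NCCN1`, < 100000 nM (a limit of the assay, not a number)
compound 2 `CCCCn1ncnc1-c1ccccc1NCC1=NCCN1`, 200 nM
compound 3 `Cn1ncnc1-c1ccccc1NCC1=NCCN1`, 2 nM

Compound 1 stands only as a limit in this assay, so its place among the numbers is open; the shared core carries an isopropyl on the azole nitrogen. Compound 4 `CCCn1nccc1-c1ccccc1NCC1=NCCN1` is not yet measured; (propyl in place of isopropyl on an aromatic nitrogen). Within the data shown here, the one measured step that bears on the alkyl group at this position is a 100-fold lower number from compound 2 to compound 3 (2.00 log units; beyond the scatter), which favours the smaller group. Compound 4 keeps the same count of carbons as compound 1, so no step beyond the scatter is expected from the rearrangement alone. Compound 4 is therefore estimated at 300 nM, between 30 nM and 3000 nM, which means an expected step that the limit leaves unreadable from compound 1 to compound 4.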

Compound 4, half-maximal effective concentration: 251 nM
Compound 4: the middle estimate sits 1.2-fold (0.08 log units) above what was measured; low and high end bracket the measured number.
By their numbers in this assay, from the lowest: compound 3; then compounds 2 and 4 (each within the scatter of the next).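

No step can be read from compound 1 to compound 4, as compound 1 stands only as a limit of the assay, not a number: the limit of < 100000 nM in this assay, at which 1 of the 4 values shown sits.

The compounds shown leave open how propyl and isopropyl on the aromatic nitrogen compare.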